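Amide aryl variation on a shared pyrrolopyrimidine-type series

The compounds below may be only part of what the source reports. "The series", "measured", "known", "first", "only" and "open" are said of these compounds alone.

Measured so far:
- compound 1, `CN(C)C(=O)c1cc2cnc(Nc3ccc(NC(=O)C4(C(=O)Nc5ccccc5)CC4)cc3)nc2n1C1CCCC1`: 93.9%
- compound 2, `CN(C)C(=O)c1cc2cnc(Nc3ccc(NC(=O)C4(C(=O)Nc5cccc(O)c5)CC4)cc3)nc2n1C1CCCC1`: 83.7%

In a functional assay on T47D cells (Homo sapiens) for inhibition, read by CCK-8 assay, with a stated time of 72 h, tested at 10 uM (a higher number here means more inhibition of growth at the concentration tested, a lower number less inhibition of growth), compound 1 gives 93.9%, and compound 2 gives 83.7%. Going by the values given here, compound 2 therefore stands lowest of the two numbers recorded, with compound 1 as its only neighbour; the single step between them, a number 10.2 percentage points lower from compound 1 to compound 2 (beyond the scatter), is beyond the scatter but modest.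

The next compound, compound 3, `CN(C)C(=O)c1cc2cnc(Nc3ccc(NC(=O)C4(C(=O)Nc5ccc(Cl)cc5)CC4)cc3)nc2n1C1CCCC1`, is not yet measured. Relative to compound 2 the change is 4-chlorophenyl in place of 3-hydroxyphenyl on an amide-type nitrogen. Among the compounds with values here, no measured step covers this exact change. Within the data shown here, the only step in hand, a number 10.2 percentage points lower from compound 1 to compound 2 (beyond the scatter), concerns a hydroxy in place of hydrogen on an aromatic carbon; compound 3 carries no hydroxy on that ring, so the nearest reference point on the numbers is compound 1 rather than compound 2.

For compound 3 the expected step from compound 2 is a number 6.3 percentage points higher from compound 2 to compound 3 (within the scatter), an upward move because compound 1 stands at 93.9% without the hydroxy. The estimate for compound 3 is 90%, in the range 78% to 97%.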

Compound 3, percent growth inhibition at one concentration: 95%
Compound 3: middle estimate off by 5 percentage points, on the low side, and the stated range covers the measured number.
By their numbers in this assay, from the lowest: compound 2; then compounds 1 and 3 (each within the scatter of the next).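

At the amide-type nitrogen, the result in this assay shows that the ring tolerates a substituent other than hydroxy without a clear loss: the step on adding a chloro to this ring is a number 1.1 percentage points higher from compound 1 to compound 3 (within the scatter). The earlier drop with hydroxy therefore does not extend to every substituent on this ring, and the series now has a number 11.3 percentage points higher from compound 2 to compound 3 (beyond the scatter), with 4-chlorophenyl in place of 3-hydroxyphenyl. Nothing on hand accounts for either step, and the numbers give no reason for the difference between hydroxy and chloro.

The step between 3-hydroxyphenyl and 4-chlorophenyl changes both the substituent and its place on the ring, so these two contributions remain unseparated, and a single tested concentration gives no way to tell compound 1 and compound 3 apart. Also open, as far as these compounds go, is how the series would respond to a carboxylic acid, a dimethylamino group or a methoxy on this ring, or to a saturated ring such as cyclohexyl in place of the phenyl on the amide-type nitrogen.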